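A piperidin-1-yl group on an amide-type nitrogen

The source may report more compounds than this note shows. Statements on the series, on what has been measured and on what is new or still open speak of the compounds shown alone.

Compound 3 `Cc1cc(C(N)=O)nn1Cc1cc(Cl)ccc1OCC(C)C` gives 3.1 in a physicochemical assay for lipophilicity, at pH 7.4 (a lower number here means a more polar compound, a higher number a more lipophilic compound), and holds the lower of the two numbers there, with compound 1 `Cc1cc(C(N)=O)nn1Cc1cc(Cl)ccc1OCc1ccccc1` nearest at 3.7 on that scale. Compound 2 `Cc1cc(C(=O)NCc2ccccn2)nn1Cc1cc(Cl)ccc1OCc1ccccc1` reads > 3.7 and this is a limit. Compound 4 `Cc1cc(C(=O)NN2CCCCC2)nn1Cc1cc(Cl)ccc1OCC(C)C` differs from compound 3 by piperidin-1-yl in place of hydrogen on an amide-type nitrogen as piperidin-1-yl in place of hydrogen on an amide-type nitrogen. Within the data shown here, the closest precedent is a number no lower from compound 1 to compound 2 (the limit leaves the size open) with (pyridin-2-yl)methyl at that same kind of nitrogen. The other step, a number 0.60 log units lower from compound 1 to compound 3 (beyond the scatter), lies elsewhere and only sets the starting level. A modest rise in this assay is therefore expected, estimated as a number 0.70 log units higher from compound 3 to compound 4 (beyond the scatter) overall. Compound 4 is expected at 3.8 with an estimated range of 3.3 to 4.3 in this reading.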

Compound 4, distribution coefficient: 3.3
Compound 4: middle estimate off by 0.50 log units, on the high side; the range from low to high includes it.
By their numbers in this assay, from the lowest: compounds 3 and 4 (each within the scatter of the next); then compound 1.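

In this assay, among these compounds, piperidin-1-yl in place of hydrogen on an amide-type nitrogen gives the first step of readable size at this position: a number 0.20 log units higher from compound 3 to compound 4 (within the scatter). This group on that nitrogen thus leaves the two compounds within the scatter of each other. The earlier step at this kind of nitrogen cannot be read, and compound 2 stands at a limit, not a number: the limit of > 3.7 in this assay, at which 1 of the 4 values shown sits.

On these data alone, what a morpholin-4-yl group or a longer chain on this nitrogen would read remains open. Also open, as far as these compounds go, is whether piperidin-1-yl would give the same step on the core of compound 1.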